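A few compounds are considered here, and "the series" means these few. Any claim that something is new, unique, unknown or untested is made for them only; others in the source may bear on it.

Measured so far:
compound 1 `CC(C)c1ccc(-c2cc(-c3ccc4c(c3)CCCC4)nc(Cl)c2C#N)cc1`: 8400 nM in an ADME assay on RAW264.7 cells (Mus musculus) for cytotoxicity, with a stated time of 24 h; on this read-out higher numbers stand for weaker inhibition and lower numbers for stronger inhibition
compound 2 `CCOC(=O)COc1nc(-c2ccc3c(c2)CCCC3)cc(-c2ccc(OC)c(OC)c2)c1C#N`: 26200 nM in this assay

In this assay compound 2 holds the highest of the two numbers; the nearest, compound 1, sits lower by a margin beyond the scatter. Compound 3 `CCOC(=O)COc1nc(-c2ccc3c(c2)CCCC3)cc(-c2ccc(C(C)C)cc2)c1C#N` has not been measured. It differs from compound 2 in one place: 4-isopropylphenyl in place of 3,4-dimethoxyphenyl on an aromatic carbon. Among the measured compounds shown here, no pair of measured compounds isolates this change. For the measured compounds named here, compound 1 carries the same 4-isopropylphenyl group but differs from compound 2 in a second place as well, so the two values show only that the isopropylphenyl-bearing compound 1 gives the lower number. Going by the values given here, with that as the only guide, a downward move from compound 2 to compound 3 is expected, of moderate size, estimated as a 1.7-fold lower number from compound 2 to compound 3 (0.24 log units; within the scatter). For compound 3 the expected value is 15000 nM, with a range of 6000 nM to 40000 nM.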

Compound 3, half-maximal inhibitory concentration: > 50000 nM
Compound 3: only a limit was reported; the forecaster's own chance of this, stated with the estimate: 15%; middle value at least 3.3-fold (0.52 log units) away from the limit.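

Compound 3 gives only a limit of the assay, not a number: the limit of > 50000 nM in this assay, at which 1 of the 3 values shown sits.

Opposite the ring nitrogen, 4-isopropylphenyl in place of 3,4-dimethoxyphenyl reads in this assay as an at least 1.9-fold higher number from compound 2 to compound 3 (0.28 log units; that floor lies within the scatter), so this change gives no lower number, though the true size of the move stays unknown. With 4-isopropylphenyl held constant, (ethoxycarbonyl)methoxy in place of chloro reads as an at least 5.9-fold higher number from compound 1 to compound 3 (0.77 log units; beyond the scatter), so among the compounds shown the lower number follows the chloro group and not the 4-isopropylphenyl group.

On these data alone, how far either step extends past its floor remains open. Also open, as far as these compounds go, are how a free carboxylic acid in place of the ethyl ester, or an amine in place of chloro, would read, and whether a single methoxy group on the phenyl ring would behave like the 3,4-dimethoxyphenyl group.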